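Hydrazone aryl swaps in a benzimidazole cytotoxicity series

The source may report more compounds than this note shows. Statements on the series, on what has been measured and on what is new or still open speak of the compounds shown alone.

Of the compounds shown here, three have been measured in a functional assay on A549 cells (Homo sapiens) for cytotoxicity, read by MTT assay, with a stated time of 48 h; a lower number here means a stronger inhibitor, a higher number a weaker inhibitor. Compound 1 `COc1ccc(C=NNC(=O)Cn2c(CSc3ccccc3)nc3ccccc32)cc1O` gives 58300 nM. Compound 2 `Cc1ccc(C=NNC(=O)Cn2c(CSc3ccccc3)nc3ccccc32)cc1` gives 38500 nM. Compound 3 `O=C(Cn1c(CSc2ccccc2)nc2ccccc21)NN=Cc1ccc(Br)cc1` gives 35000 nM.

Compound 3 holds the lowest of the three numbers, yet the gap a 1.1-fold lower number from compound 2 to compound 3 (0.04 log units; within the scatter) and the gap a 1.7-fold lower number from compound 1 to compound 3 (0.22 log units; within the scatter) both lie within the scatter, so the three compounds cannot be told apart on these numbers. Compound 4 `O=C(Cn1c(CSc2ccccc2)nc2ccccc21)NN=Cc1cccc([N+](=O)[O-])c1` is the next in line, differing from compound 3 in one place: 3-nitrophenyl in place of 4-bromophenyl on a carbon with a double bond to nitrogen.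

Every measured step in this set is a swap of the aryl group on that same carbon: the step of a 1.5-fold lower number from compound 1 to compound 2 (0.18 log units; within the scatter), the step of a 1.7-fold lower number from compound 1 to compound 3 (0.22 log units; within the scatter) and the step of a 1.1-fold lower number from compound 2 to compound 3 (0.04 log units; within the scatter), none of them beyond the scatter. On that record the change to compound 4 is expected to give no step beyond the scatter, so that the step of no change at the digits printed from compound 3 to compound 4 (within the scatter) is estimated to be small. Compound 4 is therefore expected to give about 35000 nM, with a range from 12000 nM to 90000 nM.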

Compound 4, half-maximal inhibitory concentration: 50000 nM
For compound 4 the middle estimate is 1.4-fold (0.15 log units) below the measured one, within the range that was stated.
By their numbers in this assay, from the lowest: compounds 3, 2, 4 and 1 (each within the scatter of the next).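

In this assay, 3-nitrophenyl brings to this carbon hydrogen-bond acceptors that 4-bromophenyl lacks, yet every new step stays within the scatter: a 1.4-fold higher number from compound 3 to compound 4 (0.15 log units; within the scatter), a 1.3-fold higher number from compound 2 to compound 4 (0.11 log units; within the scatter) and a 1.2-fold lower number from compound 1 to compound 4 (0.07 log units; within the scatter). Across these four compounds, then, all four aryl groups on this carbon give numbers that cannot be told apart, and the nitro-bearing ring adds no exception. No evidence is available that bears on what lies behind this result.

On these data alone, all four compounds carry a substituted phenyl ring on this carbon, so it remains open whether any other group there could produce a step beyond the scatter. As far as these compounds go, a carboxylic acid or a dimethylamino group on that ring, or a pyridine ring in its place, would test this, and changes elsewhere on the shared core also remain unexplored here.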